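Trading the Aryl Ester for a Propanoyl Group

A few compounds are considered here, and "the series" means these few. Any claim that something is new, unique, unknown or untested is made for them only; others in the source may bear on it.

Measured compounds:
- compound 1 `O=C(OC1(C(=O)Nc2ccc([N+](=O)[O-])cc2)CCCCC1)c1ccc(C(F)(F)F)cc1`: 27.1 nM
- compound 2 `O=C(OC1(C(=O)Nc2ccc([N+](=O)[O-])cc2)CCCCC1)c1ccc(Br)cc1`: 237 nM
- compound 3 `O=C(OC1(C(=O)Nc2ccc([N+](=O)[O-])cc2)CCCCC1)c1ccccc1`: 903 nM

In a functional assay on MCF7 cells (Homo sapiens) for inhibition, read by MTT assay, with a stated time of 72 h (a higher number here means a weaker inhibitor, a lower number a stronger inhibitor), compound 2 sits second highest of the three, with compound 3 nearest at a 3.8-fold higher number from compound 2 to compound 3 (0.58 log units; beyond the scatter) and compound 1 furthest at an 8.7-fold higher number from compound 1 to compound 2 (0.94 log units; beyond the scatter). Compound 4 `CCC(=O)OC1(C(=O)Nc2ccc([N+](=O)[O-])cc2)CCCCC1` carries the change (ethyl in place of 4-bromophenyl on a carbonyl carbon), so the whole aromatic ring of compound 2 is gone. Going by the values given here, the only steps that speak to this are the ones on that ring: the stripping of bromo, a 3.8-fold higher number from compound 2 to compound 3 (0.58 log units; beyond the scatter), and the stripping of trifluoromethyl, a 33-fold higher number from compound 1 to compound 3 (1.52 log units; beyond the scatter), both weakening. Removing the ring itself is a bigger cut than either, so a weakening step beyond the scatter is expected, an 11-fold higher number from compound 2 to compound 4 (1.02 log units; beyond the scatter). Compound 4 is therefore estimated at 2500 nM, within 600 nM to 10000 nM.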

Compound 4, half-maximal inhibitory concentration: 14.1 nM
For compound 4 the middle estimate is 180-fold (2.25 log units) above the measured one; the whole stated range lies above it.
By their numbers in this assay, from the lowest: compounds 4 and 1 (each within the scatter of the next); then compound 2; then compound 3.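

Dropping the aromatic ring at this carbonyl carbon does not cost activity in this assay: ethyl in place of 4-bromophenyl gives a 17-fold lower number from compound 2 to compound 4 (1.23 log units; beyond the scatter), and ethyl in place of phenyl gives a 64-fold lower number from compound 3 to compound 4 (1.81 log units; beyond the scatter). Ethyl also matches the 4-(trifluoromethyl)phenyl group, with a 1.9-fold lower number from compound 1 to compound 4 (0.28 log units; within the scatter), so an aromatic ring is not required here, even though removing its substituents weakened the compounds. No available evidence accounts for this result. Still open, on these data alone, is how a longer chain, a methyl group or an amine would fare on this carbonyl carbon.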